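Phenylsulfanyl in place of pentylamino on the purine riboside

This account rests on a few compounds, and the source may have more. Where it says the series, first, only, none or still open, it means among the compounds named here.

Within the data shown here, compound 2 `CCCCCNc1ncnc2c1ncn2[C@@H]1O[C@H](CO)[C@@H](O)[C@H]1O` gives the lowest of the two numbers in an assay on isolated protein for binding affinity to Equilibrative nucleoside transporter 1 (Homo sapiens) (on this read-out higher numbers stand for weaker inhibition and lower numbers for stronger inhibition), with 13500 nM; compound 1 `O=[N+]([O-])c1cccc2c1CCN(c1ncnc3c1nc1n3[C@@H]3O[C@H](CO1)[C@@H](O)[C@H]3O)C2` sits far higher at 7410000 nM, and no single-change step connects the two. Compound 3 `OC[C@H]1O[C@@H](n2cnc3c(Sc4ccccc4)ncnc32)[C@H](O)[C@@H]1O` is not yet measured in this assay. Its change from compound 2: phenylsulfanyl in place of pentylamino on an aromatic carbon. Among the measured compounds shown here, with no measured step of this kind, the expectation is a lower number beyond the scatter, estimated as a 6.8-fold lower number from compound 2 to compound 3 (0.83 log units; beyond the scatter). For compound 3 in this assay the estimate is 2000 nM, within 300 nM to 15000 nM.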

Compound 3, half-maximal inhibitory concentration: 91200 nM
Compound 3: middle estimate off by 46-fold (1.66 log units), on the low side; the measured number lies above the stated range.
By their numbers in this assay, from the lowest: compound 2; then compound 3; then compound 1.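

In this assay, the aromatic carbon next to the ring nitrogen proves sensitive to a single change: phenylsulfanyl in place of pentylamino gives a 6.8-fold higher number from compound 2 to compound 3 (0.83 log units; beyond the scatter). At this position, the aromatic ring carried through sulfur therefore does not improve on the open pentylamino chain. Nothing available explains the step. On these data alone, whether the sulfur link, the phenyl ring or the loss of the amino hydrogen-bond donor drives the change remains open. Pentylsulfanyl and phenylamino would separate these contributions.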